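Nitro in place of hydroxy: compound 2 to compound 4

The compounds below may be only part of what the source reports. "The series", "measured", "known", "first", "only" and "open" are said of these compounds alone.

Of the compounds shown here, three of a shared core have been measured in a functional assay on HUVEC cells (Homo sapiens), read by fluorescence and microscopy, with a stated time of 6 h, tested at 10 uM; a lower number here means a stronger effect, a higher number a weaker effect of the compound at the concentration tested. Compound 1 `COc1cccc(Nc2sc3ccccc3c2C#N)c1` gives 81%. Compound 2 `N#Cc1c(Nc2ccc(O)cc2)sc2ccccc12` gives 25%, the lowest of the three numbers and thus the strongest effect at the concentration tested; both other values lie beyond the scatter above it. Compound 3 `CC(=O)N(c1ccc(O)cc1)c1sc2ccccc2c1C#N` gives 36%. For the measured compounds named here, the only single-place step among the measured compounds is a number 11 percentage points higher from compound 2 to compound 3 (beyond the scatter), a modest rise. Compound 1 and compound 2 differ in more than one place; their two values merely show a wide gap.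

Compound 4 `N#Cc1c(Nc2ccc([N+](=O)[O-])cc2)sc2ccccc12` remains to be measured. It differs from compound 2 as follows: nitro in place of hydroxy on an aromatic carbon. Going by the values given here, no measured step covers this exact change. Among the compounds with values here, the acetyl step is the only precedent for altering compound 2 in one place, and it shows a modest upward move; the change here removes the single hydrogen-bond donor of that ring while adding acceptors, for which the series holds no direct example.

Compound 4 is therefore expected at 45%, with a range of 25% to 70%. The expected step is a number 20 percentage points higher from compound 2 to compound 4 (beyond the scatter), upward, since compound 2 sits at the low end of the series with 25% and any sizeable move from it is more likely to weaken than to strengthen the effect.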

Compound 4, a percentage reported as activity, at one concentration (the size of the read-out at that concentration, not a potency): 8%
For compound 4 the middle estimate is 37 percentage points above the measured one; measured number outside the range, below it.
By their numbers in this assay, from the lowest: compound 4; then compound 2; then compound 3; then compound 1.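

In this assay, for the compounds shown here, nitro in place of hydroxy on an aromatic carbon para to a large group gives a number 17 percentage points lower from compound 2 to compound 4 (beyond the scatter), the first single-place change to lower the number rather than raise it. The hydroxy group, with its hydrogen-bond donor, is therefore not required at this position for the effect seen at the concentration tested, since nitro carries no such donor and the number still falls. Nothing measured here accounts for the direction of this step.

The data do not separate a benefit of nitro itself from a benefit of losing hydroxy, and a carboxylic acid or an amine on the same aromatic carbon would help make that distinction, as would plain hydrogen there. Also open, from the compounds shown here alone, is whether the modest rise seen with acetyl on the nitrogen, a number 11 percentage points higher from compound 2 to compound 3 (beyond the scatter), would recur with nitro on the ring, and whether these single-concentration read-outs would hold as potencies.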